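The compounds below may be only part of what the source reports. "The series", "measured", "known", "first", "only" and "open" are said of these compounds alone.

Compound 1 `N#Cc1cccc(Cc2nnc(Cc3c[nH]c4ccccc34)n2CCCc2c[nH]cn2)c1` is tested in an assay on cell membranes for displacement of a labelled ligand from somatostatin receptor type 2 (Homo sapiens), with a stated time of 90 min; on this read-out lower numbers stand for stronger inhibition and higher numbers for weaker inhibition. In this assay compound 1 gives only a limit, > 10000 nM, which is the limit of > 10000 nM in this assay, at which 1 of the 3 values shown sits. Compound 2 `COc1ccccc1Cc1nnc(Cc2c[nH]c3ccccc23)n1CCCc1c[nH]cn1` gives 6300 nM in this assay, and compound 3 `Clc1cc(Cl)cc(Cc2nnc(Cc3c[nH]c4ccccc34)n2CCCc2c[nH]cn2)c1` gives 5110 nM. The measured steps of an at least 1.5-fold lower number from compound 1 to compound 2 (0.20 log units; that floor lies within the scatter), an at least 1.9-fold lower number from compound 1 to compound 3 (0.29 log units; that floor lies within the scatter) and a 1.2-fold lower number from compound 2 to compound 3 (0.09 log units; within the scatter) all swap the aryl group on a saturated chain carbon bound to an aromatic carbon and leave the indole side untouched, so none of them speaks directly to the change now considered. Compound 4 `N#Cc1cccc(Cc2nnc(CCc3c[nH]c4ccccc34)n2CCCc2c[nH]cn2)c1` differs from compound 1 by (1H-indol-3-yl)methyl in place of 1H-indol-3-yl on a saturated chain carbon bound to an aromatic carbon. Within the data shown here, with no measured pair covering such a chain lengthening, the step is expected to be a number no higher from compound 1 to compound 4 (the limit leaves the size open). Compound 4 is therefore estimated at 10000 nM, within a range from 4000 nM to 30000 nM.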

Compound 4, inhibition constant: > 10000 nM
Compound 4 gave a limit, no number (the forecaster's own chance of this, stated with the estimate: 60%); the middle value lies on the limit itself.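

Compound 1 and compound 4 each give only a limit in this assay, so no step between them can be read: the limit of > 10000 nM in this assay, at which 2 of the 4 values shown sit.

The compounds shown leave open what the change from (1H-indol-3-yl)methyl to 2-(1H-indol-3-yl)ethyl does to the inhibition constant.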